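The source may report more compounds than this note shows. Statements on the series, on what has been measured and on what is new or still open speak of the compounds shown alone.

Compound 1, `CS/C(=N\C(=O)c1csc([N+](=O)[O-])c1)NC(=O)c1csc([N+](=O)[O-])c1`, gives 82500 nM in a functional assay on PC-3 cells (Homo sapiens) for cytotoxicity, read by MTT assay, with a stated time of 72 h; a higher number here means a weaker inhibitor of growth, a lower number a stronger inhibitor of growth. Compound 2, `C[Se]/C(=N\C(=O)c1ccno1)NC(=O)c1ccno1`, gives 39300 nM in this assay. Compound 3, `O=C(/N=C(/NC(=O)c1csc([N+](=O)[O-])c1)[Se]Cc1ccccc1)c1csc([N+](=O)[O-])c1`, gives 69200 nM in this assay.

Compound 3 sits near compound 1 and also near compound 2, both gaps being within the scatter, so none of the three can be called apart from the others. Compound 4, `C[Se]/C(=N\C(=O)c1csc([N+](=O)[O-])c1)NC(=O)c1csc([N+](=O)[O-])c1`, arises from compound 3 by hydrogen in place of phenyl on a saturated chain carbon bound to a selenium atom. Within the data shown here, the one measured step that bears on this is a 1.2-fold lower number from compound 1 to compound 3 (0.08 log units; within the scatter), which combined the benzyl-for-methyl exchange with a change of the attached atom and yet stayed within the scatter. Among the measured compounds shown here, no measured pair isolates the benzyl-to-methyl exchange on selenium alone. On that basis the expected step is a 1.1-fold higher number from compound 3 to compound 4 (0.03 log units; within the scatter), with no shift beyond the scatter. Compound 4 is therefore estimated at 75000 nM, expected to lie between 35000 nM and 160000 nM.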

Compound 4, concentration for total growth inhibition: 7090 nM
Beside the measured number, compound 4's estimate is 11-fold (1.02 log units) above it; the whole stated range lies above it.
By their numbers in this assay, from the lowest: compound 4; then compounds 2, 3 and 1 (each within the scatter of the next, the first and the last beyond it).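

In this assay, among these compounds, the group on selenium proves to count: benzyl to methyl brings a 9.8-fold lower number from compound 3 to compound 4 (0.99 log units; beyond the scatter) and so separates compound 4 from compound 3, which no earlier step had done. The atom carrying the methyl counts too, since selenium in place of sulfur brings a 12-fold lower number from compound 1 to compound 4 (1.07 log units; beyond the scatter) on the same core. Nothing available explains either step.

From the compounds shown here alone, whether ethyl or a longer chain on selenium keeps this lower number remains open. So does whether the same exchange of sulfur for selenium would act alike on the core of compound 2.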